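Halogen swap on a benzylidene cyclohexanone

This account rests on a few compounds, and the source may have more. Where it says the series, first, only, none or still open, it means among the compounds named here.

Measured compounds:
compound 1 `O=C1/C(=C/c2ccccc2)CCC/C1=C\c1ccc(F)cc1` — 34%
compound 2 `O=C1/C(=C/c2ccccc2)CCC/C1=C\c1ccc(F)c(F)c1` — 37.8%

For the measured compounds named here, in an assay on isolated protein for inhibition of Alpha glucosidase (Homo sapiens), with stated times of 5 min and 15 min, tested at 50 uM (a lower number here means less inhibition, a higher number more inhibition at the concentration tested (going by the name of the read-out)), compound 1 gives 34%, and its number lies within the scatter of the only other measured value, that of compound 2. Going by the values given here, the one measured step, a number 3.8 percentage points higher from compound 1 to compound 2 (within the scatter), concerns a different change from the one at hand and does not point either way. Compound 3 `O=C1/C(=C/c2ccccc2)CCC/C1=C\c1ccccc1Br` differs from compound 1 in one place: 2-bromophenyl in place of 4-fluorophenyl on a double-bonded chain carbon bound to a double-bonded ring carbon. Among the compounds with values here, no measured step bears on this exchange, so no step beyond the scatter is expected in this assay; for compound 3 the estimate is 35%, between 18% and 52%, an expected step of a number 1 percentage points higher from compound 1 to compound 3 (within the scatter).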

Compound 3, a percentage reported as inhibition, at one concentration (the size of the read-out at that concentration, not a potency): 46.8%
Compound 3: the middle estimate sits 11.8 percentage points below what was measured; the measured number falls inside the stated range.
By their numbers in this assay, from the lowest: compounds 1, 2 and 3 (each within the scatter of the next, the first and the last beyond it).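

In this assay, putting 2-bromophenyl in place of 4-fluorophenyl at this position gives a number 12.8 percentage points higher from compound 1 to compound 3 (beyond the scatter), a modest step but the first in this set to lie beyond the scatter. The read-out therefore responds to a change at this position, which the fluoro exchange in a number 3.8 percentage points higher from compound 1 to compound 2 (within the scatter) had not shown. Nothing available explains this step. The compounds shown leave open whether the difference follows the bromine or where it sits on the phenyl ring, and how a methoxy group or an amine there would read.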